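A few compounds are considered here, and "the series" means these few. Any claim that something is new, unique, unknown or untested is made for them only; others in the source may bear on it.

Compounds measured in an assay on brain for displacement of a labelled ligand from Adrenergic receptor alpha-1 (Rattus norvegicus); a higher number here means a weaker inhibitor, a lower number a stronger inhibitor:
- compound 1, `COc1cc2nc(N3CCC(OCCOc4ccccc4)CC3)nc(N)c2cc1OC`: 0.48 nM
- compound 2, `COc1cc2nc(N3CCC(OCC(C)OC)CC3)nc(N)c2cc1OC`: 1.41 nM
- compound 3, `COc1cc2nc(N3CCC(OCC(C)(C)OC)CC3)nc(N)c2cc1OC`: 1.14 nM

Compound 3 stands second highest of the three numbers in this assay. Its nearest neighbour is compound 2, a 1.2-fold lower number from compound 2 to compound 3 (0.09 log units; within the scatter), and its furthest is compound 1, a 2.4-fold higher number from compound 1 to compound 3 (0.38 log units; beyond the scatter).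

Compound 4, `COc1cc2nc(N3CCC(OCC(C)(C)O)CC3)nc(N)c2cc1OC`, differs from compound 3 by hydrogen in place of methyl on an oxygen on a saturated carbon. Among the compounds with values here, no measured step changes this oxygen itself; the steps that come closest all alter the group on the chain beyond it, namely a 2.9-fold higher number from compound 1 to compound 2 (0.47 log units; beyond the scatter) and a 2.4-fold higher number from compound 1 to compound 3 (0.38 log units; beyond the scatter), both modest, and a 1.2-fold lower number from compound 2 to compound 3 (0.09 log units; within the scatter). On that basis the expected step from compound 3 to compound 4 in this assay is small, a 1.4-fold higher number from compound 3 to compound 4 (0.15 log units; within the scatter), most likely within or just beyond the scatter. Compound 4 is therefore estimated at 1.6 nM, in the range 0.7 nM to 3.6 nM.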

Compound 4, inhibition constant: 1.28 nM
Estimate against measurement, compound 4: 1.3-fold (0.10 log units) above, and the stated range covers the measured number.
By their numbers in this assay, from the lowest: compound 1; then compounds 3, 4 and 2 (each within the scatter of the next).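

In this assay, hydrogen in place of methyl on this oxygen, turning methoxy into hydroxy, gives no difference beyond the scatter (a 1.1-fold higher number from compound 3 to compound 4 (0.05 log units; within the scatter)). Compound 4 likewise stays within the scatter of the chain in compound 2 (a 1.1-fold lower number from compound 2 to compound 4 (0.04 log units; within the scatter)), while the phenoxymethyl chain of compound 1 remains apart (a 2.7-fold higher number from compound 1 to compound 4 (0.43 log units; beyond the scatter)). Nothing available explains this result. Still open, going by these compounds, is whether an amine in place of the hydroxy, or an ethyl or acetyl group on this oxygen, would hold the number as well.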